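Removing the ring chloro: a step from compound 2 to compound 3

The source may hold more compounds than are shown below. What is called first, only, known or untested is meant among the compounds shown, and "the series" means these compounds.

Measured compounds:
compound 1 `CC(C)c1onc(-c2c(Cl)cccc2Cl)c1COc1ccc(-c2nc3ccc(C(=O)O)cc3n2C(C)C)cc1`, 3550 nM
compound 2 `CC(C)c1onc(-c2c(Cl)cccc2Cl)c1COc1ccc(-c2nc3ccc(C(=O)O)cc3n2C)c(Cl)c1`, 3520 nM

In an assay on HEK-293T cells for antagonist activity at vitamin D3 receptor (Homo sapiens), read by a luciferase reporter, with a stated time of 24 h (on this read-out lower numbers stand for stronger inhibition and higher numbers for weaker inhibition), compound 2 gives 3520 nM, and compound 1 gives 3550 nM, so the two stand within the usual scatter of each other. Compound 3 `CC(C)c1onc(-c2c(Cl)cccc2Cl)c1COc1ccc(-c2nc3ccc(C(=O)O)cc3n2C)cc1` has not yet been measured. Its change from compound 2 is hydrogen in place of chloro on an aromatic carbon. Among the compounds with values here, no measured pair shows this change on its own, so the step is expected to be small. Compound 3 is expected to give about 3500 nM (range 1500 nM to 8000 nM), an expected step of a 1.0-fold lower number from compound 2 to compound 3 (0.00 log units; within the scatter) that stays within the scatter.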

Compound 3, half-maximal inhibitory concentration: 7150 nM
Beside the measured number, compound 3's estimate is 2.0-fold (0.31 log units) below it; the measured number falls inside the stated range.
By their numbers in this assay, from the lowest: compounds 2, 1 and 3 (each within the scatter of the next, the first and the last beyond it).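

In this assay the chloro on this aromatic carbon, ortho to a large group and meta to a large group, now has a readable effect: hydrogen in its place gives a 2.0-fold higher number from compound 2 to compound 3 (0.31 log units; beyond the scatter) as a modest step. Methyl in place of isopropyl on the aromatic nitrogen gives a 2.0-fold higher number from compound 1 to compound 3 (0.30 log units; within the scatter) and stays within the scatter, so that change cannot be told apart from repeat variation.

Going by these compounds, whether fluoro, methoxy or an amine on this carbon would match chloro remains open. Nothing shown here explains the chloro step.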